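The source may report more compounds than this note shows. Statements on the series, on what has been measured and on what is new or still open speak of the compounds shown alone.

Compound 1 `CN1C[C@@H](c2cccs2)[C@@]2(Cc3ccccc3C2=O)[C@@]12C(=O)Nc1ccccc12` gives 32.6% in a functional assay on the whole organism (strain Wister albino) for inhibition, with Rattus norvegicus as the target, read by paw edema, with stated times of 1 h and 3 h, at a dose of 50 mg/kg by the intraperitoneal route; on this read-out lower numbers stand for less inhibition and higher numbers for more inhibition at the one dose given (going by the name of the read-out).
Compound 2 `CN1C[C@@H](c2ccc(Cl)cc2)[C@@]2(Cc3ccccc3C2=O)[C@@]12C(=O)Nc1ccccc12` gives 18.9% in this assay.
Compound 3 `CN1C(=O)[C@@]2(c3ccccc31)N(C)C[C@@H](c1ccc(Cl)cc1)[C@@]21Cc2ccccc2C1=O` gives 9.4% in this assay.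

Compound 3 holds the lowest of the three numbers; its gap to compound 2 lies within the scatter, while compound 1 stands beyond it. Compound 4 `CN1C(=O)[C@@]2(c3ccccc31)N(C)C[C@@H](c1cccs1)[C@@]21Cc2ccccc2C1=O` differs from compound 3 as follows: thiophen-2-yl in place of 4-chlorophenyl on a saturated ring carbon. The same exchange, run the other way, is seen in a number 13.7 percentage points lower from compound 1 to compound 2 (beyond the scatter), a modest loss from the thiophen-2-yl to the 4-chlorophenyl compound. The methyl step a number 9.5 percentage points lower from compound 2 to compound 3 (within the scatter) does not bear on this exchange. Applying the reverse of the first step to compound 3, the estimated change for compound 4 is a number 12.6 percentage points higher from compound 3 to compound 4 (beyond the scatter) in this assay. Compound 4 is therefore expected to give 22%, within 10% to 34%.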

Compound 4, a percentage reported as inhibition, in the whole organism at one dose (the size of the read-out at that dose, not a potency): 9.1%
For compound 4 the middle estimate is 12.9 percentage points above the measured one, outside the stated range (below it).
By their numbers in this assay, from the lowest: compounds 4, 3 and 2 (each within the scatter of the next); then compound 1.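

For the compounds shown here, with the methyl on the amide-type nitrogen, thiophen-2-yl in place of 4-chlorophenyl on the saturated ring carbon brings no readable change in this assay (a number 0.3 percentage points lower from compound 3 to compound 4 (within the scatter)), so the drop seen with the opposite exchange on the core of compound 1 has no counterpart here, though the two steps cannot be told apart: the same change on two cores in this assay, a number 13.7 percentage points lower (beyond the scatter) from compound 1 to compound 2 and a number 0.3 percentage points higher (within the scatter) from compound 4 to compound 3, 14 percentage points apart, within the scatter of two such steps.
Methyl in place of hydrogen on the amide-type nitrogen now gives a step beyond the scatter (a number 23.5 percentage points lower from compound 1 to compound 4 (beyond the scatter)), but this too cannot be told apart from the same change on the 4-chlorophenyl pair: the same change on two cores in this assay, a number 9.5 percentage points lower (within the scatter) from compound 2 to compound 3 and a number 23.5 percentage points lower (beyond the scatter) from compound 1 to compound 4, 14 percentage points apart, within the scatter of two such steps.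
The compounds shown leave open whether an amine or a carboxylic acid on this saturated ring carbon would raise the number on the core of compound 3 in this assay.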